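The source may report more compounds than this note shows. Statements on the series, on what has been measured and on what is new or still open speak of the compounds shown alone.

Working notes on the series, oxazole ketones.

Two numbers exist so far. Compound 1 `O=C(CCCCCCc1ccccc1)c1nc(Cl)co1` in an assay on isolated protein for inhibition of Fatty-acid amide hydrolase 1 (Rattus norvegicus) (on this read-out lower numbers stand for stronger inhibition and higher numbers for weaker inhibition), gives 4 nM. Compound 2 `O=C(CCCCCCc1ccccc1)c1nc(C(=O)C(F)(F)F)co1` stands at the high end of the two, and in this assay compound 2 gives 470 nM. Among the compounds with values here, the only measured step is a 120-fold higher number from compound 1 to compound 2 (2.07 log units; beyond the scatter), so exchanging chloro for (trifluoromethyl)carbonyl at this position of the shared core cost a great deal of inhibition.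

Compound 3 `O=C(CCCCCCc1ccccc1)c1nc(-c2ccccn2)co1` is not yet measured; the change from compound 2 is pyridin-2-yl in place of (trifluoromethyl)carbonyl on an aromatic carbon. Within the data shown here, no measured step covers pyridin-2-yl itself, so the expectation rests only on the removal of the (trifluoromethyl)carbonyl group. Going by these compounds, because a 120-fold higher number from compound 1 to compound 2 (2.07 log units; beyond the scatter) was large, compound 3 is expected to move back toward compound 1, a step of a 16-fold lower number from compound 2 to compound 3 (1.19 log units; beyond the scatter) in this assay, with wide uncertainty since the entering group is untested. The estimate for compound 3 in this assay is 30 nM, between 4 nM and 250 nM.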

Compound 3, inhibition constant: 1.9 nM
Compound 3: middle estimate off by 16-fold (1.20 log units), on the high side; measured number below the stated range.
By their numbers in this assay, from the lowest: compound 3; then compound 1; then compound 2.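

The position next to the ring nitrogen accepts a six-membered aromatic ring: pyridin-2-yl in place of (trifluoromethyl)carbonyl gives a 250-fold lower number from compound 2 to compound 3 (2.39 log units; beyond the scatter), although the two groups match in heavy atoms and in hydrogen-bond acceptors, so those counts alone do not set the number here. Against chloro, the same group gives a 2.1-fold lower number from compound 1 to compound 3 (0.32 log units; beyond the scatter), a modest step that leaves compound 3 with the lowest number of the three. No measurement on hand accounts for the difference between these groups.

A phenyl ring at this position would show whether the ring nitrogen of pyridin-2-yl counts for the step, and the compounds shown leave that open. Also open, going by these compounds, are how a carboxylic acid or a methyl ester would compare here, and whether the order holds with a shorter chain on the ketone.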